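From a methyl to a chlorine on the benzyl group

This account rests on a few compounds, and the source may have more. Where it says the series, first, only, none or still open, it means among the compounds named here.

Of the compounds shown here, three sharing one core have been measured in a functional assay on RAW264.7 cells (Mus musculus) for inhibition, read by Griess assay, with stated times of 2 h and 24 h; on this read-out lower numbers stand for stronger inhibition and higher numbers for weaker inhibition. Compound 1 `COc1ccc([C@@H]2CC(=O)c3c(O)cc(OCc4cn(Cc5ccccc5C(F)(F)F)nn4)cc3O2)cc1O` gives 12500 nM, compound 2 `COc1ccc([C@@H]2CC(=O)c3c(O)cc(OCc4cn(Cc5ccccc5Cl)nn4)cc3O2)cc1O` gives 6140 nM, and compound 3 `COc1ccc([C@@H]2CC(=O)c3c(O)cc(OCc4cn(Cc5cccc(C)c5)nn4)cc3O2)cc1O` gives 17400 nM. Compound 3 thus carries the highest number of the three: its nearest neighbour is compound 1, since a 1.4-fold higher number from compound 1 to compound 3 (0.14 log units; within the scatter) lies within the scatter, while its gap to compound 2, a 2.8-fold higher number from compound 2 to compound 3 (0.45 log units; beyond the scatter), goes beyond it. Between the first two, a 2.0-fold lower number from compound 1 to compound 2 (0.31 log units; beyond the scatter) is a modest change.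

Compound 4 `COc1ccc([C@@H]2CC(=O)c3c(O)cc(OCc4cn(Cc5ccc(Cl)cc5)nn4)cc3O2)cc1O` is the next step: 4-chlorophenyl in place of 3-methylphenyl on a saturated chain carbon bound to an aromatic nitrogen. Among the compounds with values here, no measured step covers this exact exchange. The closest guide is a 2.8-fold higher number from compound 2 to compound 3 (0.45 log units; beyond the scatter), where a chlorine-bearing benzyl group gave the lower number than the methyl-bearing one; compound 4, however, carries its chlorine as 4-chlorophenyl rather than 2-chlorophenyl, so that comparison is only a loose guide. Within the data shown here, the expectation for compound 4 in this assay is therefore a modest drop, a 1.9-fold lower number from compound 3 to compound 4 (0.29 log units; within the scatter), with wide uncertainty because a 2.8-fold higher number from compound 2 to compound 3 (0.45 log units; beyond the scatter) is the only step that exchanges a chlorine for a methyl. Compound 4 is estimated at 9000 nM, within a range from 4000 nM to 25000 nM.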

Compound 4, half-maximal inhibitory concentration: 17800 nM
Compound 4: the middle estimate sits 2.0-fold (0.30 log units) below what was measured, and the stated range covers the measured number.
By their numbers in this assay, from the lowest: compound 2; then compounds 1, 3 and 4 (each within the scatter of the next).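

In this assay, 4-chlorophenyl and 3-methylphenyl at this place on the saturated chain carbon cannot be told apart (a 1.0-fold higher number from compound 3 to compound 4 (0.01 log units; within the scatter)), so a chlorine on the ring does not by itself give a lower number than a methyl. Within the data shown here, what the earlier compounds could not show is that the place of the chlorine on the ring matters: 2-chlorophenyl and 4-chlorophenyl hold the same atoms, yet the exchange is a modest step beyond the scatter (a 2.9-fold higher number from compound 2 to compound 4 (0.46 log units; beyond the scatter)). Compound 4 also falls within the scatter of the compound with 2-(trifluoromethyl)phenyl (a 1.4-fold higher number from compound 1 to compound 4 (0.15 log units; within the scatter)), which leaves compound 2 alone with the lowest number of the four, while compounds 1, 3 and 4 form one group.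

Still open, on these data alone, is where 3-chlorophenyl would fall relative to the two chlorine compounds, and how the number would respond to an amine or a carboxylic acid on the ring, or to a phenethyl group in place of the benzyl group. No independent measurement is available to explain the difference between the two chlorine placements.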